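Swapping a chlorophenyl tail for pyrazole on the shared core

The source may hold more compounds than are shown below. What is called first, only, known or untested is meant among the compounds shown, and "the series" means these compounds.

Measured compounds:
- compound 1 `CC1SC(c2cccc(C(=O)NCCCCc3ccccc3)c2)N(c2ccc(C3CC3)cc2)C1=O`: 191 nM
- compound 2 `COc1ccccc1N1C(=O)CSC1c1cccc(C(=O)NCCCCc2ccc(Cl)cc2)c1`: 78.6 nM
- compound 3 `CC(C)(C)c1conc1N1C(=O)CSC1c1cccc(C(=O)NCCCCc2ccccc2)c1`: > 1000 nM

In a functional assay on HOS-TE85 cells (Homo sapiens) for inhibition, read by CCK-8 assay, with a stated time of 72 h (a lower number here means a stronger inhibitor, a higher number a weaker inhibitor), compound 2 gives 78.6 nM. This is the lowest of the two numbers reported, with compound 1 at 191 nM, a gap that lies beyond the usual scatter. Compound 3 reaches only (the limit of > 1000 nM in this assay, at which 1 of the 3 values shown sits), so for compound 3 no number is known.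

Compound 4 `COc1ccccc1N1C(=O)CSC1c1cccc(C(=O)NCCCCn2cccn2)c1` keeps the whole core of compound 2 and changes only the far end of the chain: 1H-pyrazol-1-yl in place of 4-chlorophenyl on a saturated chain carbon, four bonds along the chain from an amide-type nitrogen. Among the compounds with values here, no pair of measured compounds shows this change, so nothing here tells how large its effect is. The closest guide is that the measured compounds all carry a phenyl-type tail on that chain, and the one that stands lowest carries the 4-chlorophenyl. A weaker inhibitor is expected for compound 4 in this assay, by a step of a 3.2-fold higher number from compound 2 to compound 4 (0.50 log units; beyond the scatter). The estimate for compound 4 is 250 nM, with an expected range from 80 nM to 800 nM.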

Compound 4, half-maximal inhibitory concentration: 91.7 nM
The estimate for compound 4 lay 2.7-fold (0.44 log units) above the measured number; measured number inside the range.
By their numbers in this assay, from the lowest: compounds 2 and 4 (each within the scatter of the next); then compound 1. At a limit, above all of these: compound 3.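

In this assay, the far end of the chain accepts a clear change of ring on the core of compound 2: 1H-pyrazol-1-yl in place of 4-chlorophenyl gives a 1.2-fold higher number from compound 2 to compound 4 (0.07 log units; within the scatter), so the two compounds cannot be told apart. Within the data shown here, all the earlier compounds carried a phenyl-type tail, so they could not show that neither the all-carbon ring nor the chlorine is needed at this end of the chain to keep the number in this range. Nothing measured here explains why the two tails read alike.

Going by these compounds, whether a ring is needed at this end at all remains open, and a plain amine, a carboxylic acid or a longer chain in its place would test that. On these data alone, whether the same swap holds on the cores of compound 1 and compound 3 also remains unknown.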